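The source may report more compounds than this note shows. Statements on the series, on what has been measured and on what is new or still open speak of the compounds shown alone.

Compound 1 `C=C(C)C(=O)NC(=O)/C=C/c1cc(OC)c(OC)c(OC)c1`: in a functional assay on LNCaP cells (Homo sapiens) for inhibition, read by WST assay, with a stated time of 48 h (on this read-out lower numbers stand for stronger inhibition of growth and higher numbers for weaker inhibition of growth), compound 1 gives 10000 nM. Compound 2 `C#CCN(C(=O)/C=C/c1cc(OC)c(OC)c(OC)c1)C(=O)C(=C)C`: in this assay compound 2 gives only a limit, > 10000 nM.

Within the data shown here, compound 2 thus stands at the limit of this assay; its number is not known, and the single measured step, a number no lower from compound 1 to compound 2 (the limit leaves the size open), is open in size because of the limit of > 10000 nM in this assay, at which 1 of the 2 values shown sits. Compound 3 `C=C(C)C(=O)N(Cc1cccc(Br)c1)C(=O)/C=C/c1cc(OC)c(OC)c(OC)c1` differs from compound 2 by 3-bromophenyl in place of ethynyl on a saturated chain carbon bound to an amide-type nitrogen. Among the measured compounds shown here, no measured step touches this part of the structure, so nothing points in either direction. Compound 3 is expected to stay near the limit, an estimated step that the limit leaves unreadable from compound 2 to compound 3. For compound 3 the estimate is 12000 nM, within 4000 nM to 40000 nM.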

Compound 3, concentration for 50% growth inhibition: 10000 nM
Compound 3: middle estimate off by 1.2-fold (0.08 log units), on the high side; the measured number falls inside the stated range.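

The 3-bromobenzyl group in place of hydrogen on the amide-type nitrogen gives no change at the digits printed from compound 1 to compound 3 (within the scatter) in this assay. Among these compounds, this is the first readable comparison at this position, and it shows that a group carrying an aromatic ring leaves the printed number the same as with hydrogen. The other steps cannot be read, among them a number no higher from compound 2 to compound 3 (the limit leaves the size open), and the comparison of propargyl with 3-bromobenzyl stays open because of this: the limit of > 10000 nM in this assay, at which 1 of the 3 values shown sits.

Still open, as far as these compounds go, is whether any group on this nitrogen can give a lower number than compound 1 does. An amine, a carboxylic acid or a longer chain in this place could answer that.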